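The source may report more compounds than this note shows. Statements on the series, on what has been measured and on what is new or still open speak of the compounds shown alone.

Measured so far:
Compound 1 `NC1=NC2(CCSCC2)N(OCCCOc2cccc(Cl)c2Cl)C(N)=N1` gives 83.8%.
Compound 2 `NC1=NC2(CCSCC2)N(OCCCOc2cc(Cl)c(Cl)cc2Cl)C(N)=N1` gives 84.4%.

Both were tested in an assay on isolated protein for inhibition of Dihydrofolate reductase (Homo sapiens), read by spectrophotometry, using NADPH, with stated times of 5 s and 6 min, tested at 5 uM; a lower number here means a weaker effect, a higher number a stronger effect of the compound at the concentration tested. Within the data shown here, on the two numbers available, compound 2 carries the higher one, but the only step in hand, a number 0.6 percentage points higher from compound 1 to compound 2 (within the scatter), lies within the usual scatter, so the two compounds cannot be told apart on this evidence. Compound 3 `NC1=NC2(CCSCC2)N(OCCCOc2ccccc2Br)C(N)=N1` is the next compound in the series and has not yet been measured. It differs from compound 2 in one place: 2-bromophenyl in place of 2,4,5-trichlorophenyl on an oxygen on a saturated carbon. Among the measured compounds shown here, the single measured step is the one that bears on this change, since it also swapped one chlorinated phenyl ring for another on the same oxygen, and it moved the read-out by a number 0.6 percentage points higher from compound 1 to compound 2 (within the scatter), a shift too small to count. Nothing else in the set speaks to what a bromine in place of the chlorines might do. The expectation for this assay is therefore a step of no real size, a number 3.4 percentage points lower from compound 2 to compound 3 (within the scatter), and compound 3 is estimated to give 81%, within a range from 68% to 92%.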

Compound 3, a percentage reported as inhibition, at one concentration (the size of the read-out at that concentration, not a potency): 88.7%
Compound 3: middle estimate off by 7.7 percentage points, on the low side, and the stated range covers the measured number.
By their numbers in this assay, from the lowest: compounds 1, 2 and 3 (each within the scatter of the next).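

In this assay, replacing the 2,4,5-trichlorophenyl group with 2-bromophenyl gives a number 4.3 percentage points higher from compound 2 to compound 3 (within the scatter), and replacing the 2,3-dichlorophenyl group with 2-bromophenyl gives a number 4.9 percentage points higher from compound 1 to compound 3 (within the scatter). Among these compounds, the earlier pair showed only that one chlorinated ring could stand in for another on this oxygen, whereas these steps show that a ring with a single bromine, and with fewer heavy atoms than the 2,4,5-trichlorophenyl group, also cannot be told apart from the chlorinated rings in this read-out. Nothing in the available evidence explains why these changes leave the read-out within the scatter.

As far as these compounds go, whether a plain phenyl ring, or a ring carrying an amine or a carboxylic acid, would also stay within the scatter remains open, as does the outcome of using a longer chain on the oxygen. From the compounds shown here alone, each number is also the size of the effect at one concentration, so whether any of the three compounds would have a stronger or weaker effect at another concentration is still unknown.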